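A few compounds are considered here, and "the series" means these few. Any claim that something is new, unique, unknown or untested is made for them only; others in the source may bear on it.

Measured so far in a functional assay on MCF7 cells (Homo sapiens) for cytotoxicity, read by colorimetric assay and MTT assay; on this read-out higher numbers stand for weaker inhibition and lower numbers for stronger inhibition:

- compound 1 `COc1cccc2cc(-c3ccccc3)c(O)nc12`: 10000 nM
- compound 2 `CCOC(=O)Cn1c(=O)c(-c2ccc(OC)cc2)cc2c(OC)cc(OC)cc21`: 10000 nM

Level with compound 1, compound 2 stands at 10000 nM, and the two values lie within the usual scatter of each other. The next compound to be tested, compound 3 `COc1ccc(-c2cc3c(OC)cc(OC)cc3n(CC#N)c2=O)cc1`, keeps the core of compound 2 and changes it in one place: cyano in place of ethoxycarbonyl on a saturated chain carbon bound to an aromatic nitrogen. The same difference, cut one bond further out, reads (ethoxycarbonyl)methyl to cyanomethyl.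

Going by the values given here, no two measured compounds differ in only one place, so the data offer no direct measure of what such a change does. Among the compounds with values here, the only guide is the value of compound 2, 10000 nM, and no step beyond the scatter is expected in this assay. The expected change is a 1.1-fold lower number from compound 2 to compound 3 (0.05 log units; within the scatter). For compound 3 the estimated value is 9000 nM, with an expected range from 2500 nM to 20000 nM.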

Compound 3, half-maximal inhibitory concentration: 10000 nM
The estimate for compound 3 lay 1.1-fold (0.05 log units) below the measured number, within the range that was stated.
By their numbers in this assay, from the lowest: compounds 1, 2 and 3 (each within the scatter of the next).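

In this assay, going by these compounds alone, the exchange of ethoxycarbonyl for cyano on a saturated chain carbon bound to an aromatic nitrogen gives no change at the digits printed from compound 2 to compound 3 (within the scatter) and is the only step that can be read in this set. It shows that at this position the ethoxycarbonyl group can give way to cyano, with fewer heavy atoms and fewer hydrogen-bond acceptors, without the two compounds parting: compound 2 gives 10000 nM and compound 3 gives 10000 nM in the same assay.

On these data alone, whether an amine, a carboxylic acid or a longer chain in this place would move the number beyond the scatter remains open. Also open is whether a hydroxy group in place of a methoxy group on the shared core would separate from this level, and the one step shown cannot say how the exchange would read on a compound with a lower number. No measurement at hand accounts for this result.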